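Piperidine to piperazine on the ether chain of compound 3

A few compounds are considered here, and "the series" means these few. Any claim that something is new, unique, unknown or untested is made for them only; others in the source may bear on it.

Measured in a functional assay on A549 cells (Homo sapiens) for cytotoxicity, read by MTT assay, with a stated time of 72 h; on this read-out higher numbers stand for weaker inhibition and lower numbers for stronger inhibition:
- compound 1 `COc1cc2c(Oc3ccc(NC(=O)c4cn(-c5ccccc5Cl)nn4)cc3F)ccnc2cc1OCCCN1CCC(C)CC1`: 370 nM
- compound 2 `COc1cc2c(Oc3ccc(NC(=O)c4cn(-c5ccccc5F)nn4)cc3F)ccnc2cc1OCCCN1CCC(C)CC1`: 250 nM
- compound 3 `COc1cc2c(Oc3ccc(NC(=O)c4cn(-c5ccc(F)c(F)c5)nn4)cc3F)ccnc2cc1OCCCN1CCC(C)CC1`: 1460 nM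

Among the three measured compounds, compound 3 has the highest number: the step of a 3.9-fold higher number from compound 1 to compound 3 (0.60 log units; beyond the scatter) and the step of a 5.8-fold higher number from compound 2 to compound 3 (0.77 log units; beyond the scatter) both lie beyond the scatter, while a 1.5-fold lower number from compound 1 to compound 2 (0.17 log units; within the scatter) stays within it. All three measured steps concern the aryl group on the triazole nitrogen only.

Compound 4 `COc1cc2c(Oc3ccc(NC(=O)c4cn(-c5ccc(F)c(F)c5)nn4)cc3F)ccnc2cc1OCCCN1CCN(C)CC1` differs from compound 3 elsewhere: 4-methylpiperazin-1-yl in place of 4-methylpiperidin-1-yl on a saturated chain carbon, three bonds along the chain from an oxygen on an aromatic ring. For the measured compounds named here, no measured step touches this chain-end amine, so the measured steps give no direct guidance on its size or direction in this assay. With the rest of the molecule unchanged, the expectation for compound 4 is a step of a 1.0-fold lower number from compound 3 to compound 4 (0.02 log units; within the scatter) that stays within the scatter. Compound 4 is therefore estimated at 1400 nM, with a range from 550 nM to 3600 nM.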

Compound 4, half-maximal inhibitory concentration: 200 nM
For compound 4 the middle estimate is 7.0-fold (0.85 log units) above the measured one, outside the stated range (below it).
By their numbers in this assay, from the lowest: compounds 4, 2 and 1 (each within the scatter of the next); then compound 3.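

In this assay, the chain-end amine proves to be a responsive position: replacing 4-methylpiperidin-1-yl with 4-methylpiperazin-1-yl gives a 7.3-fold lower number from compound 3 to compound 4 (0.86 log units; beyond the scatter), a step beyond the scatter. Until now, only the aryl group on the triazole nitrogen had been seen to move the number, so activity in this series is now shown to respond at two separate places. The change is small in atom terms, with the heavy-atom total unchanged and one carbon of the group replaced by nitrogen, and no available measurement bears on why it has this effect.

As far as these compounds go, whether the same exchange acts similarly with the 2-chlorophenyl or 2-fluorophenyl group on the triazole remains open. Also open, from the compounds shown here alone, is how a morpholine, a dimethylamino group or a longer chain would behave at this position.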